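Methoxy in place of trifluoromethoxy on the shared core

A few compounds are considered here, and "the series" means these few. Any claim that something is new, unique, unknown or untested is made for them only; others in the source may bear on it.

The series rests on one shared core. Compound 1 is `CC(C)N(C(=O)CN1C=CN(c2ccccc2)C(=O)C(Cc2n[nH]c3ccccc23)C1=O)c1ccc(OC(F)(F)F)cc1`, and in a functional assay on CHO cells for agonist activity at Melanocortin receptor 4 (Homo sapiens), read by a luciferase reporter, with a stated time of 4 h (a lower number here means that less compound is needed, a higher number that more compound is needed for the effect), compound 1 gives 151 nM. Compound 2, `CC(C)N(C(=O)CN1C=CN(c2ccccc2)C(=O)C(Cc2n[nH]c3cc(F)ccc23)C1=O)c1ccc(F)cc1`, gives 178 nM in this assay, a value that sits within the scatter of the number for compound 1, so neither can be ranked above the other. Compound 3 is `CC(C)N(C(=O)CN1C=CN(c2ccccc2)C(=O)[C@@H](Cc2n[nH]c3ccccc23)C1=O)c1ccccc1`. In this assay compound 3 gives 31600 nM; > 30000 nM (2 entries), as its several entries show (the several entries of compound 3 in this assay, 31600 nM; > 30000 nM (2 entries)).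

Compound 4, `COc1ccc(N(C(=O)CN2C=CN(c3ccccc3)C(=O)C(Cc3n[nH]c4ccccc34)C2=O)C(C)C)cc1`, is not yet measured. It differs from compound 1 by methyl in place of trifluoromethyl on an oxygen on an aromatic ring. Within the data shown here, no single-change pair among the measured compounds mirrors this exchange, so the step is an estimate resting on compound 1 alone; a modest move toward a higher number is expected, a 2.6-fold higher number from compound 1 to compound 4 (0.42 log units; beyond the scatter). Compound 4 is therefore expected to give about 400 nM in this assay, with a range from 100 nM to 2000 nM.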

Compound 4, half-maximal effective concentration: 708 nM
Compound 4: the middle estimate sits 1.8-fold (0.25 log units) below what was measured, and the stated range covers the measured number.
By their numbers in this assay, from the lowest: compounds 1 and 2 (each within the scatter of the next); then compound 4.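

In this assay, the exchange of trifluoromethyl for methyl on an oxygen on an aromatic ring is the only single-change step shown, and it gives a 4.7-fold higher number from compound 1 to compound 4 (0.67 log units; beyond the scatter). This shows that the group on this oxygen matters to the number, although the step is modest and compound 4 still gives a measurable 708 nM. Nothing measured here gives a reason for the step.

The compounds shown leave open how a longer chain on the same oxygen, such as ethyl or propyl, would read, and how an amine or a carboxylic acid in place of the whole trifluoromethoxy group would read. From the compounds shown here alone, it also remains open whether the same exchange would give a step of similar size elsewhere, since this single pair is all that supports it.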